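The compounds below may be only part of what the source reports. "The series", "measured", "known", "first", "only" and "open" are said of these compounds alone.

Of the compounds shown here, two that share one core have been measured. In an assay on isolated protein for inhibition of Rho-associated protein kinase 1 (Homo sapiens), read by scintillation counting, radiometric assay and 33P incorporation, with a stated time of 40 min, in the presence of a further agent that is not named here (on this read-out higher numbers stand for weaker inhibition and lower numbers for stronger inhibition), compound 1 `CN(C)c1ccc(C(=O)Nc2cccc(NC(=O)COc3ccc4c(c3)NC(=O)CC4)c2)cc1` reports > 10000 nM, which is a limit of the assay rather than a number; this sits at the limit of > 10000 nM in this assay, at which 1 of the 2 values shown sits. Compound 2 `CC(=O)Nc1cccc(NC(=O)COc2ccc3c(=O)ccoc3c2)c1` is the one compound with a number: in this assay compound 2 gives 2500 nM, the only number shown. Compound 3 `CCCC(=O)Nc1cccc(NC(=O)COc2ccc3c(=O)ccoc3c2)c1` differs from compound 2 by ethyl in place of hydrogen on a saturated chain carbon bound to a carbonyl carbon. For the measured compounds named here, no step between two measured compounds is available, and nothing measured speaks to lengthening this chain. The change brings no ring, no donor and no acceptor. No movement beyond the usual scatter is expected, with at most a slight gain in inhibition; the expected step is a 1.3-fold lower number from compound 2 to compound 3 (0.10 log units; within the scatter). Compound 3 is therefore estimated at about 2000 nM, between 700 nM and 6000 nM.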

Compound 3, half-maximal inhibitory concentration: 1430 nM
Compound 3: middle estimate off by 1.4-fold (0.15 log units), on the high side, within the range that was stated.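

The first step read at this position comes from this assay: ethyl in place of hydrogen on a saturated chain carbon bound to a carbonyl carbon, which turns acetamido into (propylcarbonyl)amino, gives a 1.7-fold lower number from compound 2 to compound 3 (0.24 log units; within the scatter). On this read-out compound 2 and compound 3 cannot be told apart, so this position carries the added ethyl with no change that can be distinguished from ordinary repeat variation. Nothing measured here offers an explanation for the size of this step.

From the compounds shown here alone, it remains open whether a longer chain, a phenyl ring or an amine at this position would shift inhibition beyond the scatter. A single step on a single core also cannot show whether the same change would behave alike on a different core.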